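Cytotoxicity notes: hydroxypyrrolidinyl in place of cyclohexylamino

The source may report more compounds than this note shows. Statements on the series, on what has been measured and on what is new or still open speak of the compounds shown alone.

Compound 2 `COc1cc2cc(C#N)ccc2c(OC)c1Oc1cc(NC2CCCCC2)nc(Nc2ccc(C#N)cc2)n1` is scored in an ADME assay on MT4 cells (Homo sapiens) for cytotoxicity, read by MTT assay, with a stated time of 5 days; on this read-out higher numbers stand for lower toxicity in this test and lower numbers for higher toxicity in this test. There compound 2 gives > 125000 nM, a limit of the assay rather than a number. Compound 1 `COc1cc2cc(C#N)ccc2c(OC)c1Oc1cc(NCC(C)C)nc(Nc2ccc(C#N)cc2)n1` gives > 125000 nM in this assay, likewise a limit. The only measured step, a step that the two limits leave unreadable from compound 1 to compound 2, therefore has no readable size, as shown by the limit of > 125000 nM in this assay, at which 2 of the 2 values shown sit. Compound 3 `COc1cc2cc(C#N)ccc2c(OC)c1Oc1cc(N2CCC(O)C2)nc(Nc2ccc(C#N)cc2)n1` carries 3-hydroxypyrrolidin-1-yl in place of cyclohexylamino on an aromatic carbon. For the measured compounds named here, no measured step bears on this change, so no shift beyond the scatter is expected, and compound 3 is expected to remain at the limit, an estimated step that the limit leaves unreadable from compound 2 to compound 3. For compound 3 the estimate is 150000 nM, with a range from 60000 nM to 400000 nM.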

Compound 3, half-maximal cytotoxic concentration: > 125000 nM
Compound 3 gave a limit, no number (the forecaster's own chance of this, stated with the estimate: 85%); the middle value lies beyond the limit too.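

No step among compound 1, compound 2 and compound 3 can be read in this assay, as each result is a limit and not a number: the limit of > 125000 nM in this assay, at which 3 of the 3 values shown sit.

Going by these compounds, whether any group at this place on the shared core gives a measurable value in this assay stays open.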